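The source may report more compounds than this note shows. Statements on the series, on what has been measured and on what is new or still open speak of the compounds shown alone.

Measured so far in a functional assay on V79-379A cells (Cricetulus griseus) for cytotoxicity, read by MTT assay, in the presence of a further agent that is not named here; on this read-out higher numbers stand for weaker inhibition and lower numbers for stronger inhibition: compound 1 `COC1=CC(=O)c2c(c(COC(=O)c3ccccc3F)cn2C)C1=O` gives 500 nM; compound 2 `COC1=CC(=O)c2c(c(COC(=O)c3ccccc3F)c(C)n2C)C1=O` gives 164000 nM; compound 3 `COC1=CC(=O)c2c(c(COC(N)=O)cn2C)C1=O` gives 3000 nM.

Two changes separate these three. The first, (methyl in place of hydrogen on an aromatic carbon), brings a 330-fold higher number from compound 1 to compound 2 (2.52 log units; beyond the scatter). The second, (amino in place of 2-fluorophenyl on a carbonyl carbon), brings a 6.0-fold higher number from compound 1 to compound 3 (0.78 log units; beyond the scatter).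

Compound 4 `COC1=CC(=O)c2c(c(COC(N)=O)c(C)n2C)C1=O` is not yet measured in this assay. It carries the change (methyl in place of hydrogen on an aromatic carbon). Going by the values given here, this is the same kind of change as the one from compound 1 to compound 2, not the same: there the ring atom next to the changed carbon bears a large group, here it bears a (carbamoyloxy)methyl group (5 heavy atoms). The cores of compound 3 and compound 4 differ from those of compound 1 and compound 2 by amino in place of 2-fluorophenyl on a carbonyl carbon only.

Among the compounds with values here, for compound 4 the step in this assay is expected to be a 200-fold higher number from compound 3 to compound 4 (2.30 log units; beyond the scatter), resting on the single earlier example a 330-fold higher number from compound 1 to compound 2 (2.52 log units; beyond the scatter), with wider uncertainty because only one such step is known. Compound 4 is therefore estimated at 600000 nM, with a range from 100000 nM to 3000000 nM.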

Compound 4, half-maximal inhibitory concentration: 25000 nM
Estimate against measurement, compound 4: 24-fold (1.38 log units) above; the whole stated range lies above it.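

In this assay methyl in place of hydrogen gives an 8.3-fold higher number from compound 3 to compound 4 (0.92 log units; beyond the scatter) and so moves the number the same way as on the core of compound 1, but by a different amount: the same change on two cores in this assay, a 330-fold higher number (2.52 log units; beyond the scatter) from compound 1 to compound 2 and an 8.3-fold higher number (0.92 log units; beyond the scatter) from compound 3 to compound 4, 39-fold (1.60 log units) apart, beyond the scatter of two such steps

Amino in place of 2-fluorophenyl gives a 6.6-fold lower number from compound 2 to compound 4 (0.82 log units; beyond the scatter) and so runs the opposite way to its step without the added methyl: the same change on two cores in this assay, a 6.0-fold higher number (0.78 log units; beyond the scatter) from compound 1 to compound 3 and a 6.6-fold lower number (0.82 log units; beyond the scatter) from compound 2 to compound 4, 39-fold (1.60 log units) apart, beyond the scatter of two such steps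

Neither step therefore carries unchanged from one core to another in these four compounds, though each comparison rests on a single pair and the reason for the difference is not shown.

Open, from the compounds shown here alone, is whether an ethyl group or a chlorine atom in place of the added methyl behaves like the methyl. Also open, going by these compounds, is how a methylamino or phenyl group in place of the amino or 2-fluorophenyl would respond to that methyl.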